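The source may report more compounds than this note shows. Statements on the series, on what has been measured and on what is new or still open speak of the compounds shown alone.

Of the compounds shown here, three built on one shared core have been tested in a functional assay on RS4-11 cells (Homo sapiens) for inhibition, read by CCK-8 assay, with a stated time of 48 h, tested at 20 uM; on this read-out higher numbers stand for more inhibition of growth at the one concentration tested and lower numbers for less inhibition of growth. Compound 1 `N#C/C(=C\c1ccccc1OS(=O)(=O)c1ccc([N+](=O)[O-])cc1)C(=O)Nc1nnc(Cc2ccc(Cl)cc2)s1` gives 66%. Compound 2 `N#C/C(=C\c1ccccc1OS(=O)(=O)c1ccccc1[N+](=O)[O-])C(=O)Nc1nnc(Cc2ccc(Cl)cc2)s1` differs from compound 1 by 2-nitrophenyl in place of 4-nitrophenyl on a sulfonyl sulfur, and in this assay compound 2 gives 65%, so that a number 1 percentage points lower from compound 1 to compound 2 (within the scatter). Compound 3 `Cc1ccc(Cc2nnc(NC(=O)/C(C#N)=C/c3ccccc3OS(=O)(=O)c3ccc([N+](=O)[O-])cc3)s2)cc1` differs from compound 1 by methyl in place of chloro on an aromatic carbon, and in this assay compound 3 gives 64%, so that a number 2 percentage points lower from compound 1 to compound 3 (within the scatter). Compound 4 `Cc1ccc(Cc2nnc(NC(=O)/C(C#N)=C/c3ccccc3OS(=O)(=O)c3ccccc3[N+](=O)[O-])s2)cc1` has not yet been measured in this assay. Among the measured compounds shown here, it differs from compound 3 by 2-nitrophenyl in place of 4-nitrophenyl on a sulfonyl sulfur, which is the same change, at the same place, as the one from compound 1 to compound 2, now made on the core of compound 3 instead of the core of compound 1. Because a number 1 percentage points lower from compound 1 to compound 2 (within the scatter), compound 4 is expected to show a step of a number 1 percentage points lower from compound 3 to compound 4 (within the scatter). Compound 4 is therefore estimated at 63%, with a likely range from 53% to 73%.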

Compound 4, percent growth inhibition at one concentration: "not active" (no number reported)
Compound 4: no number reported; no gap can be computed for the estimate.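

Among the compounds shown here, compound 4 is reported as "not active" without a number in this assay, so no step from compound 3 to compound 4 can be read, and no supporting data bear on this result. From the compounds shown here alone, whether 2-nitrophenyl in place of 4-nitrophenyl acts differently on the core of compound 3 than on the core of compound 1 remains open.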